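A Nitro Group Replaces a Methyl on the Phenoxy Arm

The compounds below may be only part of what the source reports. "The series", "measured", "known", "first", "only" and "open" are said of these compounds alone.

Of the compounds shown here, three sharing one core have been tested in an assay for inhibition of prostacyclin synthase (Homo sapiens), using microsomes; a lower number here means a stronger inhibitor, a higher number a weaker inhibitor. Compound 1 `O=C(O)CC/C=C\CC1COC(c2ccc([N+](=O)[O-])cc2)OC1c1cccnc1` gives 13000 nM. Compound 2 `O=C(O)CC/C=C\CC1COC(c2ccc(Cl)cc2Cl)OC1c1cccnc1` gives 2500 nM, and the step of a 5.2-fold lower number from compound 1 to compound 2 (0.72 log units; beyond the scatter) shows how far that single change reached. Compound 3 `Cc1ccc(OC(C)(C)C2OCC(C/C=C\CCC(=O)O)C(c3cccnc3)O2)cc1` gives 25000 nM, the highest of the three numbers; against compound 1 the two values lie within the usual scatter, while against compound 2 the gap lies beyond it. Compound 4 `CC(C)(Oc1ccccc1[N+](=O)[O-])C1OCC(C/C=C\CCC(=O)O)C(c2cccnc2)O1` carries 2-nitrophenyl in place of 4-methylphenyl on an oxygen on a saturated carbon. Going by the values given here, only one measured step exists, and it sits on a different position of the core, so it offers weak guidance for this change. Compound 4 is therefore expected to change little, a 1.3-fold lower number from compound 3 to compound 4 (0.10 log units; within the scatter), and is estimated in this assay at 20000 nM, between 7000 nM and 60000 nM.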

Compound 4, half-maximal inhibitory concentration: < 1000 nM
Compound 4 was reported as a limit; the forecaster's own chance of this, stated with the estimate: 10%; middle value at least 20-fold (1.30 log units) from the limit.
By their numbers in this assay, from the lowest: compound 2; then compounds 1 and 3 (each within the scatter of the next). At a limit, below all of these: compound 4.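

On this arm of the core, 2-nitrophenyl in place of 4-methylphenyl on an oxygen on a saturated carbon gives an at least 25-fold lower number from compound 3 to compound 4 (1.39 log units; beyond the scatter) in this assay. Going by these compounds alone, the only earlier step lay at a different position, so this is the first sign that the group on this oxygen can move the number strongly. The figure for compound 4 is a limit, not an exact value, so the true size of the step stays unknown: the limit of < 1000 nM in this assay, at which 1 of the 4 values shown sits.

The compounds shown leave open whether the nitro group itself or its place on the ring matters more. From the compounds shown here alone, it also remains open whether an amine or a carboxylic acid on the same ring would give a similar number.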